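Swapping Phenoxy for Dimethylamino on a Cytotoxic Scaffold

A few compounds are considered here, and "the series" means these few. Any claim that something is new, unique, unknown or untested is made for them only; others in the source may bear on it.

Of the compounds shown here, three that share a core have been tested in a functional assay on SN12C cells (Homo sapiens) for cytotoxicity, read by sulforhodamine B assay, with a stated time of 48 h, tested at 100 nM; a lower number here means a stronger effect, a higher number a weaker effect of the compound at the concentration tested. Compound 1 `COc1cc(C)cc(-c2c(-c3ccnc(-c4ccc(C(C)=O)cc4)c3)cnn2CC#N)c1` gives 92%, compound 2 `COc1cc(C)cc(-c2nn(CC#N)cc2-c2ccc(-c3cccc(C(C)=O)c3)nc2)c1` gives 91%, and compound 3 `Cc1cc(O)cc(-c2nn(CC#N)cc2-c2ccnc(-c3ccc(Oc4ccccc4)cc3)c2)c1` gives 86%. Compound 3 has the lowest of the three numbers, but its gap to compound 2 and to compound 1 lies within the usual scatter, so no ordering among them can be claimed. Compound 4 `Cc1cc(O)cc(-c2nn(CC#N)cc2-c2ccnc(-c3ccc(N(C)C)cc3)c2)c1` differs from compound 3 in one place: dimethylamino in place of phenoxy on an aromatic carbon. Going by the values given here, no two measured compounds differ in only one place, so no step size can be read from the data. The expected step of a number 1 percentage points higher from compound 3 to compound 4 (within the scatter) is small, not beyond the scatter. Compound 4 is estimated at 87%, with a range from 75% to 98%.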

Compound 4, a percentage reported as activity, at one concentration (the size of the read-out at that concentration, not a potency): 91%
Compound 4: middle estimate off by 4 percentage points, on the low side; the range from low to high includes it.
By their numbers in this assay, from the lowest: compounds 3, 2, 4 and 1 (each within the scatter of the next).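

In this assay, going by these compounds alone, this is the first pair differing in one place, and it gives a number 5 percentage points higher from compound 3 to compound 4 (within the scatter). On this aromatic carbon, para to a large group, dimethylamino and phenoxy therefore cannot be told apart, even though dimethylamino has no ring and fewer heavy atoms. No outside evidence accompanies this result.

Going by these compounds, it remains open whether a carboxylic acid or a longer chain such as a butoxy group at this position would move the number beyond the scatter. On these data alone, the role of the hydroxyl group elsewhere on the shared core also remains open.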